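From 2-chlorophenyl to 3-chlorophenyl: a step still unmeasured

The source may hold more compounds than are shown below. What is called first, only, known or untested is meant among the compounds shown, and "the series" means these compounds.

Of the compounds shown here, three sharing one core have been tested in a functional assay on K562 cells (Homo sapiens) for cytotoxicity, read by sulforhodamine B assay; a higher number here means that more compound is tolerated, a lower number that less compound is tolerated. Compound 1 `CC1=CC[C@@H]([C@@](C)(O)CCCC(C)(C)NC(=S)N/N=C\c2ccccc2[N+](=O)[O-])CC1`, with 2-nitrophenyl, gives > 100000 nM, and this value is a limit, not a number. Compound 2 `CC1=CC[C@@H]([C@@](C)(O)CCCC(C)(C)NC(=S)N/N=C\c2cccc([N+](=O)[O-])c2)CC1`, with 3-nitrophenyl, gives 12600 nM. Compound 3 `CC1=CC[C@@H]([C@@](C)(O)CCCC(C)(C)NC(=S)N/N=C\c2ccccc2Cl)CC1`, with 2-chlorophenyl, gives 8500 nM. Among the compounds with values here, compound 3 therefore stands level with its only numerical neighbour, as the data show a 1.5-fold lower number from compound 2 to compound 3 (0.17 log units; within the scatter). Against the limit of compound 1, the data show an at least 11-fold lower number from compound 1 to compound 3 (1.07 log units; beyond the scatter).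

Compound 4 `CC1=CC[C@@H]([C@@](C)(O)CCCC(C)(C)NC(=S)N/N=C\c2cccc(Cl)c2)CC1` carries 3-chlorophenyl in place of 2-chlorophenyl on a carbon with a double bond to nitrogen. Within the data shown here, the closest precedent is the matching swap among the nitro compounds, which gives an at least 7.9-fold lower number from compound 1 to compound 2 (0.89 log units; beyond the scatter). Going by these compounds, that step starts from a limit, so its true size is unknown. It need not carry over, since compound 3 gives 8500 nM. Compound 2, with 12600 nM, suggests that a group on the 3-substituted phenyl can give a number in this same region. No step beyond the scatter is therefore expected, and the estimated change is a 1.2-fold higher number from compound 3 to compound 4 (0.07 log units; within the scatter). For compound 4 the expected value is 10000 nM, within an estimated range of 4000 nM to 30000 nM.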

Compound 4, concentration lethal to 50% of the cells: 56300 nM
The estimate for compound 4 lay 5.6-fold (0.75 log units) below the measured number; the measured number lies above the stated range.
By their numbers in this assay, from the lowest: compounds 3 and 2 (each within the scatter of the next); then compound 4. At a limit, above all of these: compound 1.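

Compound 4 shows that the position of the chloro group matters here: the swap of 2-chlorophenyl for 3-chlorophenyl gives a 6.6-fold higher number from compound 3 to compound 4 (0.82 log units; beyond the scatter) and thus runs opposite to the nitro pair, where the data give an at least 7.9-fold lower number from compound 1 to compound 2 (0.89 log units; beyond the scatter) from a limit. Between the two compounds with the group on the same place, the data give a 4.5-fold higher number from compound 2 to compound 4 (0.65 log units; beyond the scatter) and so the swap of chloro for nitro has no single direction, its outcome depending on where on the phenyl ring the change is made: the same change on two cores in this assay, an at least 11-fold lower number (1.07 log units; beyond the scatter) from compound 1 to compound 3 and a 4.5-fold higher number (0.65 log units; beyond the scatter) from compound 2 to compound 4, at least 52-fold (1.72 log units) apart, beyond the scatter of two such steps. The value of compound 1 is a limit, so an at least 1.7-fold lower number from compound 1 to compound 4 (0.24 log units; that floor lies within the scatter) gives only a floor and compound 4 cannot be firmly set apart from compound 1: the limit of > 100000 nM in this assay, at which 1 of the 4 values shown sits.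

The compounds shown leave open whether this reversal is peculiar to chloro and nitro or would also appear with a methoxy group or an amine on the phenyl ring. They also leave open how far the true value of compound 1 lies beyond its limit, and with it the real size of the nitro step.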